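A few compounds are considered here, and "the series" means these few. Any claim that something is new, unique, unknown or untested is made for them only; others in the source may bear on it.

Compound 2 `O=C(CNC1CCCCC1)N1N=C(c2cc3ccccc3oc2=O)CC1c1ccccc1` is the weaker of the two measured compounds in a functional assay on PC-3 cells (Homo sapiens) for cytotoxicity, read by MTT assay, with a stated time of 48 h; on this read-out higher numbers stand for weaker inhibition and lower numbers for stronger inhibition: compound 2 gives 48500 nM, whereas compound 1 `CCC(=O)N1N=C(c2cc3ccccc3oc2=O)CC1c1ccccc1`, which carries a methyl on the saturated chain carbon bound to the carbonyl carbon, gives 4370 nM. Among the compounds with values here, the only measured step, an 11-fold higher number from compound 1 to compound 2 (1.05 log units; beyond the scatter), concerns the introduction of the cyclohexylamino group and is large.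

Compound 3 `CC1CCCCN1CC(=O)N1N=C(c2cc3ccccc3oc2=O)CC1c1ccccc1` is an isomer of compound 2 in which (2-methylpiperidin-1-yl in place of cyclohexylamino on a saturated chain carbon bound to a carbonyl carbon). Within the data shown here, no measured step covers this exchange: the one step known, from compound 1 to compound 2, compares a methyl with a cyclohexylamino group, and compound 3 keeps the same atom count on that chain while removing the hydrogen-bond donor. The step from compound 1 to compound 2 therefore bears on it only indirectly, showing that this part of the molecule can move the number substantially.

Among the measured compounds shown here, with no direct precedent, compound 3 is expected to stay close to compound 2, with a modest shift at most, so the estimated step is a 1.4-fold lower number from compound 2 to compound 3 (0.14 log units; within the scatter). Compound 3 is estimated at 35000 nM in this assay, with a range from 10000 nM to 120000 nM.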

Compound 3, half-maximal inhibitory concentration: 36300 nM
For compound 3 the middle estimate is 1.0-fold (0.02 log units) below the measured one; low and high end bracket the measured number.
By their numbers in this assay, from the lowest: compound 1; then compounds 3 and 2 (each within the scatter of the next).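

In this assay, the exchange of cyclohexylamino for 2-methylpiperidin-1-yl on the saturated chain carbon bound to the carbonyl carbon comes to a 1.3-fold lower number from compound 2 to compound 3 (0.13 log units; within the scatter), so compounds 2 and 3 cannot be told apart, although the hydrogen-bond donor counted for cyclohexylamino is absent from 2-methylpiperidin-1-yl. The large gap from the methyl compound therefore no longer rests on a single group: an 8.3-fold higher number from compound 1 to compound 3 (0.92 log units; beyond the scatter) shows a second seven-heavy-atom group on the same side of compound 1 as cyclohexylamino, with an 11-fold higher number from compound 1 to compound 2 (1.05 log units; beyond the scatter) as the earlier step. Nothing available explains why these two groups read alike or why both differ from methyl.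

As far as these compounds go, it remains open whether piperidin-1-yl without its methyl, morpholin-4-yl or an open-chain group such as dimethylamino would fall with compounds 2 and 3, or nearer to compound 1. Also open, from the compounds shown here alone, is how a smaller amino group, a longer chain between the carbonyl and the amine, or a carboxylic acid at this place would read on these cells.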